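Replacing Ethyl with Hydrogen on the Ring Nitrogen

This account rests on a few compounds, and the source may have more. Where it says the series, first, only, none or still open, it means among the compounds named here.

Measured compounds:
- compound 1 `O=C1CS/C(=N/Nc2nncc3ccccc23)N1c1ccccc1`: 47 nM
- compound 2 `CCN1C(=O)CS/C1=N/Nc1nncc2ccccc12`: 58 nM

In a functional assay on HT-29 cells (Homo sapiens) for antiproliferative activity, read by sulforhodamine B assay, with a stated time of 72 h (on this read-out higher numbers stand for weaker inhibition and lower numbers for stronger inhibition), compound 2 gives 58 nM, which lies within the scatter of compound 1 at 47 nM. Going by the values given here, with only two values measured, neither compound can be separated from the other.

Compound 3 `O=C1CS/C(=N/Nc2nncc3ccccc23)N1` keeps the core of compound 2 and carries hydrogen in place of ethyl on an amide-type nitrogen in a ring.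

Among the compounds with values here, only one measured step bears on this change: a 1.2-fold higher number from compound 1 to compound 2 (0.09 log units; within the scatter), with ethyl in place of phenyl at the same nitrogen. Within the data shown here, that exchange of two quite different groups left the number within the scatter, so the series so far shows little response at this place. Among the measured compounds shown here, it is a single step, however, and no measured compound has hydrogen on this nitrogen, so the extrapolation is weak.

No change beyond the scatter is expected in this assay, with a slight lean towards a higher number. The expected step is a 1.5-fold higher number from compound 2 to compound 3 (0.17 log units; within the scatter). Compound 3 is estimated at 85 nM, with an expected range of 30 nM to 260 nM.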

Compound 3, half-maximal inhibitory concentration: 49 nM
Estimate against measurement, compound 3: 1.7-fold (0.24 log units) above; the range from low to high includes it.
By their numbers in this assay, from the lowest: compounds 1, 3 and 2 (each within the scatter of the next).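

With hydrogen on the ring nitrogen, this assay gives a 1.2-fold lower number from compound 2 to compound 3 (0.07 log units; within the scatter) and a 1.0-fold higher number from compound 1 to compound 3 (0.02 log units; within the scatter). Hydrogen, ethyl and phenyl at this place thus all lie within the scatter of one another, so for these three compounds the number does not depend on whether the nitrogen carries a carbon group at all, something the single earlier step between ethyl and phenyl could not show. No measurement at hand explains why this position responds so little to the change.

Going by these compounds, all three compounds vary only this nitrogen, so whether a longer chain ending in an amine or a carboxylic acid would also stay within the scatter remains open. On these data alone, the response to changes elsewhere on the shared core, and whether the same flat picture holds outside this single cell line, also remain open.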